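Phenylsulfonyl replaces sec-butoxycarbonyl in a flat series

The source may report more compounds than this note shows. Statements on the series, on what has been measured and on what is new or still open speak of the compounds shown alone.

Compound 1 `O=C(Nc1ccc(O)c2c(=O)cc(-c3ccccc3Cl)oc12)c1ccccc1` gives 13000 nM
Compound 2 `Cc1ccc(C(=O)Nc2ccc(O)c3c(=O)cc(-c4ccccc4Cl)oc23)cc1` gives 16000 nM
Compound 3 `CCC(C)OC(=O)Nc1ccc(O)c2c(=O)cc(-c3ccccc3Cl)oc12` gives 18000 nM

These values all come from a functional assay on ID8 cells (Mus musculus) for antiproliferative activity; on this read-out lower numbers stand for stronger inhibition and higher numbers for weaker inhibition. Compound 3 stands level with the other two, since its value lies within the scatter of both, and no ranking can be drawn among the three.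

The unmeasured compound 4 `O=c1cc(-c2ccccc2Cl)oc2c(NS(=O)(=O)c3ccccc3)ccc(O)c12` differs from compound 3 on one group: phenylsulfonyl in place of sec-butoxycarbonyl on a nitrogen on an aromatic ring. In words, this is phenylsulfonyl in place of sec-butoxycarbonyl on a nitrogen on an aromatic ring.

The closest evidence comes from changes at the carbonyl carbon, which gave a 1.4-fold higher number from compound 1 to compound 3 (0.14 log units; within the scatter) and a 1.1-fold higher number from compound 2 to compound 3 (0.05 log units; within the scatter). The methyl change gave a 1.2-fold higher number from compound 1 to compound 2 (0.09 log units; within the scatter). All three steps stay within the scatter. Going by the values given here, no measured step removes the carbonyl itself, so the expectation remains loose.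

The expected step is a 1.3-fold lower number from compound 3 to compound 4 (0.11 log units; within the scatter), which is nothing beyond the scatter. For compound 4 the estimated value is 14000 nM in this assay. The expected range for compound 4 runs from 5000 nM to 35000 nM.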

Compound 4, half-maximal inhibitory concentration: 9500 nM
Estimate against measurement, compound 4: 1.5-fold (0.17 log units) above; low and high end bracket the measured number.
By their numbers in this assay, from the lowest: compounds 4, 1, 2 and 3 (each within the scatter of the next).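

In this assay, going by these compounds alone, the earlier compounds carried only carbonyl-linked groups on the nitrogen on an aromatic ring, and compound 4 extends the picture to a sulfonyl link at this place. Phenylsulfonyl in place of sec-butoxycarbonyl gives a small step (a 1.9-fold lower number from compound 3 to compound 4 (0.28 log units; within the scatter)), as does phenylsulfonyl in place of (4-methylphenyl)carbonyl (a 1.7-fold lower number from compound 2 to compound 4 (0.23 log units; within the scatter)) and in place of benzoyl (a 1.4-fold lower number from compound 1 to compound 4 (0.14 log units; within the scatter)), so exchanging any of these three carbonyl-linked groups for phenylsulfonyl leaves compound 4 level with the others. No measurement shown accounts for how closely these values sit together.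

The compounds shown leave open whether methylsulfonyl or a free amine on this nitrogen would move the number beyond the scatter. They also leave open whether a chlorine or a methoxy group on the phenylsulfonyl ring would do so.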